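Swapping a pyridine for a tolyl ring on a thiophene core

The source may hold more compounds than are shown below. What is called first, only, known or untested is meant among the compounds shown, and "the series" means these compounds.

The measured compounds:
Compound 1, `Clc1cccc(-c2cc(-c3ccc(Cl)o3)cc(-c3cccs3)n2)c1`: 12800 nM
Compound 2, `Clc1ccc(-c2cc(-c3cccnc3)nc(-c3ccsc3)c2)o1`: > 50000 nM
Compound 3, `Clc1ccc(-c2cc(-c3cccnc3)nc(-c3cccs3)c2)o1`: 14600 nM

All three were tested in a functional assay on HeLa cells (Homo sapiens) for cytotoxicity, in the presence of a further agent that is not named here; a lower number here means a stronger inhibitor, a higher number a weaker inhibitor. Compound 1 gives 12800 nM and compound 3 gives 14600 nM. For compound 2 the assay reports only a limit, > 50000 nM, so compound 2 stands at the weak end of the numbers shown, at the limit of > 50000 nM in this assay, at which 1 of the 3 values shown sits.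

The step from compound 2 to compound 4, `Cc1ccccc1-c1cc(-c2ccc(Cl)o2)cc(-c2ccsc2)n1`, is this change: 2-methylphenyl in place of pyridin-3-yl on an aromatic carbon

Among the measured compounds shown here, two measured steps bear on it. The step of a 1.1-fold higher number from compound 1 to compound 3 (0.06 log units; within the scatter) exchanges an aryl ring for a pyridin-3-yl group at the same kind of position and stays within the scatter. The step of an at least 3.4-fold lower number from compound 2 to compound 3 (0.53 log units; beyond the scatter) concerns the other ring and is not altered here; compound 4 keeps the thiophen-3-yl group of compound 2. Going from compound 2 to compound 4 is therefore expected to bring no step in this assay beyond the scatter, with a fair chance that only a limit is reported again.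

Compound 4 is thus estimated at 60000 nM, with a range from 20000 nM to 200000 nM. That estimate means an expected step that the limit leaves unreadable from compound 2 to compound 4.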

Compound 4, half-maximal inhibitory concentration: 9770 nM
Compound 4: the middle estimate sits 6.1-fold (0.79 log units) above what was measured; measured number outside the range, below it.
By their numbers in this assay, from the lowest: compounds 4, 1 and 3 (each within the scatter of the next). At a limit, above all of these: compound 2.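

In this assay, the place on the shared core that is next to the ring nitrogen proves sensitive to the group it carries: 2-methylphenyl in place of pyridin-3-yl gives an at least 5.1-fold lower number from compound 2 to compound 4 (0.70 log units; beyond the scatter). The earlier exchange at this kind of place, a 1.1-fold higher number from compound 1 to compound 3 (0.06 log units; within the scatter), stayed within the scatter, but it involved a different aryl group and a core bearing thiophen-2-yl, whereas the new step has thiophen-3-yl on the core, so a flat result in one setting does not carry over to the other. The value of compound 2 is a limit and not a number, so the new step has a lower bound but no exact size: the limit of > 50000 nM in this assay, at which 1 of the 4 values shown sits.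

The compounds shown leave open whether the methyl group of the 2-methylphenyl ring matters or whether an unsubstituted phenyl ring, a 3-methylphenyl ring or a 4-methylphenyl ring would serve as well at this place. They also do not tell whether the same exchange would produce a step beyond the scatter with thiophen-2-yl on the core, or how an amine or a carboxylic acid on this aryl ring would read.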